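The source may hold more compounds than are shown below. What is called first, only, known or untested is meant among the compounds shown, and "the series" means these compounds.

The three measured compounds share one core and differ in the five-membered ring carried on the amide carbonyl and in the side chain on the benzylic carbon. Compound 1 `CC(C)C[C@H](N)c1cc(C(F)(F)F)ccc1N1CCN(C(=O)[C@H]2C[S+]([O-])C[C@@H]2c2ccc(Cl)cc2)CC1` gives 120 nM in an assay on HEK293 cells for displacement of a labelled ligand from Melanocortin receptor 4 (Homo sapiens); on this read-out higher numbers stand for weaker inhibition and lower numbers for stronger inhibition. Compound 2 `CNCCC(=O)N[C@@H](CC(C)C)c1cc(C(F)(F)F)ccc1N1CCN(C(=O)[C@H]2CSC[C@@H]2c2ccc(Cl)cc2)CC1` gives 170 nM in this assay. Compound 3 `Cc1ccc(N2CCN(C(=O)[C@@H]3CCO[C@@H]3c3ccc(Cl)cc3)CC2)c([C@@H](NC(=O)CCN(C)C)C(C)C)c1` gives 120 nM in this assay, which is level with compound 1 at the digits shown and within the scatter of compound 2, so all three sit close together.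

Compound 4 `Cc1ccc(N2CCN(C(=O)[C@@H]3OCC[C@@H]3c3ccc(Cl)cc3)CC2)c([C@@H](NC(=O)CCN(C)C)C(C)C)c1` has the same atoms as compound 3 joined differently: 3-(4-chlorophenyl)oxolan-2-yl in place of 2-(4-chlorophenyl)oxolan-3-yl on a carbonyl carbon. Among the compounds with values here, no measured pair shows what such a rearrangement of the oxolane does, so the expectation rests on compound 3 alone. A change of this kind is estimated to give at most a modest step, with the direction uncertain, and a 1.7-fold higher number from compound 3 to compound 4 (0.22 log units; within the scatter) is the expected step; compound 4 is therefore expected to give about 200 nM in this assay, within a range from 60 nM to 700 nM.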

Compound 4, inhibition constant: 10 nM
For compound 4 the middle estimate is 20-fold (1.30 log units) above the measured one; the measured number lies below the stated range.
By their numbers in this assay, from the lowest: compound 4; then compounds 1, 3 and 2 (each within the scatter of the next).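

In this assay, putting 3-(4-chlorophenyl)oxolan-2-yl in place of 2-(4-chlorophenyl)oxolan-3-yl on a carbonyl carbon gives a 12-fold lower number from compound 3 to compound 4 (1.08 log units; beyond the scatter). Within the data shown here, the two groups have the same atoms and the same counts of rings, hydrogen-bond donors and acceptors, so this position responds strongly to how the atoms are joined, something the earlier compounds, with their closely grouped values and no single-place pair, could not show. Nothing available explains why this arrangement gives the lower number.

The compounds shown leave open whether an amine nitrogen in place of the ring oxygen of 3-(4-chlorophenyl)oxolan-2-yl would keep the low number. They also leave open whether the same rearrangement would give a step of like size with the sulfur-containing rings and side chains of compound 1 and compound 2.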